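The source may hold more compounds than are shown below. What is called first, only, known or untested is meant among the compounds shown, and "the series" means these compounds.

Measured in a functional assay on HepG2 cells (Homo sapiens) for antiproliferative activity, read by MTT assay, with a stated time of 24 h; a higher number here means a weaker inhibitor, a lower number a stronger inhibitor:
- compound 1 `Cc1ccc(-c2nn(-c3ccccc3)cc2-c2nc3ccccc3[nH]2)cc1`: 6260 nM
- compound 2 `COc1ccc(S(=O)(=O)n2c(-c3cn(-c4ccccc4)nc3-c3ccc(F)cc3)nc3ccccc32)cc1`: 470 nM
- compound 3 `COc1ccc(S(=O)(=O)n2c(-c3cn(-c4ccccc4)nc3-c3ccc(C(F)(F)F)cc3)nc3ccccc32)cc1`: 370 nM

Compound 3 stands level with compound 2 within the scatter, and compound 1 has a much higher number than either. Compound 4 `O=S(=O)(c1ccc(Br)cc1)n1c(-c2cn(-c3ccccc3)nc2-c2ccc(C(F)(F)F)cc2)nc2ccccc21` is the next to read, with this change: bromo in place of methoxy on an aromatic carbon. This turns 4-methoxyphenyl into 4-bromophenyl on the sulfonyl. Among the compounds with values here, the only measured step, a 1.3-fold lower number from compound 2 to compound 3 (0.10 log units; within the scatter), lies within the scatter and involves a different group, so the series holds no direct measure of this swap. Within the data shown here, with only that small step to go on, no shift beyond the scatter is expected in this assay, and no direction is favoured. The expected change is a 1.1-fold higher number from compound 3 to compound 4 (0.06 log units; within the scatter). The estimate for compound 4 is 420 nM, with a range of 170 nM to 1000 nM.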

Compound 4, half-maximal inhibitory concentration: 2160 nM
Compound 4: middle estimate off by 5.1-fold (0.71 log units), on the low side, and the stated range ends below it.
By their numbers in this assay, from the lowest: compounds 3 and 2 (each within the scatter of the next); then compound 4; then compound 1.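

In this assay, within the data shown here, the change from (4-methoxyphenyl)sulfonyl to (4-bromophenyl)sulfonyl gives a 5.8-fold higher number from compound 3 to compound 4 (0.77 log units; beyond the scatter), the first single-place step beyond the scatter. This aromatic carbon is therefore sensitive to its substituent, with methoxy preferred over bromo in the trifluoromethyl-bearing compounds. Nothing available explains the shift.

Among these compounds, with only two groups compared here, it remains open whether methoxy helps or bromo harms. An amine, a hydroxyl or plain hydrogen at this carbon would help separate the two, and the same swap on fluoro-bearing compound 2 would test whether the step carries over.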